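Swapping a para isopropyl for a nitrile

The source may hold more compounds than are shown below. What is called first, only, known or untested is meant among the compounds shown, and "the series" means these compounds.

Compound 1, `CC(=O)Nc1cccc(C2CCN(CCCn3c(-c4cccc(Cl)c4)nc4ccccc43)CC2)c1`: in an assay for displacement of a labelled ligand from melanin-concentrating hormone receptor 1 (Homo sapiens), read by fluorescence (a lower number here means a stronger inhibitor, a higher number a weaker inhibitor), compound 1 gives 5 nM.
Compound 2, `CC(=O)Nc1cccc(C2CCN(CCCn3c(-c4ccc(C(C)C)cc4)nc4ccccc43)CC2)c1`: in this assay compound 2 gives 60 nM.

Within the data shown here, of the two numbers measured, compound 2 stands highest, and the only step so far, a 12-fold higher number from compound 1 to compound 2 (1.08 log units; beyond the scatter), separates it from compound 1. That step changes both the substituent and its position on the ring at once, so it speaks only indirectly to the next change.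

Compound 3, `CC(=O)Nc1cccc(C2CCN(CCCn3c(-c4ccc(C#N)cc4)nc4ccccc43)CC2)c1`, is made from compound 2 by one change: cyano in place of isopropyl on an aromatic carbon. Among the measured compounds shown here, no measured pair shows this exact exchange. What is known is that the para isopropyl of compound 2 sits on the weaker end of the two numbers, which leaves room for a smaller para group to give a lower number, but without a direct precedent the direction is uncertain. Compound 3 is therefore expected to give about 30 nM, within a range from 8 nM to 120 nM. That estimate amounts to an expected step of a 2.0-fold lower number from compound 2 to compound 3 (0.30 log units; within the scatter).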

Compound 3, half-maximal inhibitory concentration: 16 nM
Beside the measured number, compound 3's estimate is 1.9-fold (0.27 log units) above it; the range from low to high includes it.
By their numbers in this assay, from the lowest: compound 1; then compound 3; then compound 2.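

With the position held fixed, this change can be read on its own: in this assay cyano in place of isopropyl gives a 3.8-fold lower number from compound 2 to compound 3 (0.57 log units; beyond the scatter). The earlier step altered the group and its place together. The cyano group does not close the whole gap, as 4-cyanophenyl in place of 3-chlorophenyl gives a 3.2-fold higher number from compound 1 to compound 3 (0.51 log units; beyond the scatter) and leaves compound 1 with the lower number of the two. Nothing measured here explains either step, and the reason for the difference between these groups remains unknown.

The remaining gap between compound 1 and compound 3 mixes two differences, the group and its place on the ring, and only a pair such as 3-cyanophenyl against 4-cyanophenyl, or 4-chlorophenyl against 3-chlorophenyl, would pull them apart. From the compounds shown here alone, it also remains open how other groups on this ring carbon would read in this assay, for example a methoxy group, an amine or a carboxylic acid.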